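Fluorophenyl position across the shared core

This account rests on a few compounds, and the source may have more. Where it says the series, first, only, none or still open, it means among the compounds named here.

Measured so far in a functional assay on HCT-15 cells (Homo sapiens) for inhibition; on this read-out higher numbers stand for weaker inhibition and lower numbers for stronger inhibition:
compound 1 `Oc1cccc(-c2cc(-c3cccc(F)c3)cc(-c3ccccc3O)n2)c1` — compound 1 gives > 50000 nM
compound 2 `Oc1ccc(-c2cc(-c3ccccc3F)cc(-c3ccccc3O)n2)cc1` — compound 2 gives > 50000 nM

For compound 2 this assay reports only a limit, not a number; compound 2 sits at the limit of > 50000 nM in this assay, at which 2 of the 2 values shown sit. Compound 1 likewise returns only a limit. Compound 3 `Oc1ccc(-c2cc(-c3cccc(F)c3)cc(-c3ccccc3O)n2)cc1` differs from compound 2 by 3-fluorophenyl in place of 2-fluorophenyl on an aromatic carbon. Among the compounds with values here, with no measured step between related compounds to lean on, no change beyond the scatter is expected from compound 2 to compound 3, and a limit again seems the likeliest outcome. Compound 3 is expected near 50000 nM, within 20000 nM to 150000 nM, an expected step of a number no higher from compound 2 to compound 3 (the limit leaves the size open).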

Compound 3, half-maximal inhibitory concentration: > 50000 nM
Compound 3 ended at the assay's limit; the forecaster's own chance of this, stated with the estimate: 85%; the middle value lies on the limit itself.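

No step can be read from compound 2 to compound 3 or from compound 1 to compound 3, because all three return only a limit: the limit of > 50000 nM in this assay, at which 3 of the 3 values shown sit.

The compounds shown leave open whether 3-fluorophenyl and 2-fluorophenyl, or 4-hydroxyphenyl and 3-hydroxyphenyl, differ at all in this assay.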